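The source may report more compounds than this note shows. Statements on the series, on what has been measured and on what is new or still open speak of the compounds shown alone.

Going by the values given here, in a functional assay on MCF7 cells (Homo sapiens) for cytotoxicity, read by MTT assay, with a stated time of 72 h (on this read-out higher numbers stand for weaker inhibition and lower numbers for stronger inhibition), compound 1 (`O=C(N/N=C/c1cccc(Br)c1)Nc1cc2c(Nc3ccc(F)c(Cl)c3)ncnc2cc1O[C@H]1CCOC1`) gives 12400 nM and compound 3 (`COc1cc2ncnc(Nc3ccc(F)c(Cl)c3)c2cc1NC(=O)N/N=C/c1cccc(Br)c1`) gives 27100 nM as the higher of the only two numbers. Compound 2 (`O=C(N/N=C/c1ccc([N+](=O)[O-])cc1)Nc1cc2c(Nc3ccc(F)c(Cl)c3)ncnc2cc1O[C@H]1CCOC1`) is reported as "not active" (no number reported) with no number. Among the compounds with values here, the one measured step is a 2.2-fold higher number from compound 1 to compound 3 (0.34 log units; beyond the scatter) and it is modest, but it concerns a different change. Compound 4 (`COc1cc2ncnc(Nc3ccc(F)c(Cl)c3)c2cc1NC(=O)N/N=C/c1ccc([N+](=O)[O-])cc1`) differs from compound 3 by 4-nitrophenyl in place of 3-bromophenyl on a carbon with a double bond to nitrogen. The closest guide is that compound 2, which also carries 4-nitrophenyl, is "not active" (no number reported) while compound 1 gives 12400 nM as a number. The expected change is a 2.0-fold higher number from compound 3 to compound 4 (0.31 log units; beyond the scatter) and points towards weaker inhibition in this assay with no number also possible. Compound 4 is estimated at 55000 nM with an expected range from 25000 nM to 120000 nM as its limits.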

Compound 4, half-maximal inhibitory concentration: 36800 nM
Estimate against measurement, compound 4: 1.5-fold (0.17 log units) above; low and high end bracket the measured number.
By their numbers in this assay, from the lowest: compound 1; then compounds 3 and 4 (each within the scatter of the next).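

In this assay, 4-nitrophenyl in place of 3-bromophenyl on the carbon with a double bond to nitrogen gives a 1.4-fold higher number from compound 3 to compound 4 (0.13 log units; within the scatter), so with methyl on the oxygen this position accepts the exchange without a change beyond the scatter. Compound 2 carries the same 4-nitrophenyl and is reported as "not active", so that group does not lead to this report in every compound. No measured evidence bears on this result. As far as these compounds go, whether an amine or a carboxylic acid on that phenyl ring would read any differently remains open.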